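Fluoro for Methoxy on the Benzylamide of Compound 2

The compounds below may be only part of what the source reports. "The series", "measured", "known", "first", "only" and "open" are said of these compounds alone.

Two compounds share a hydroxyurea core carrying an alkyne-linked aryl amide. Compound 1 `C[C@H](C#Cc1cccc(C(=O)NCCC(c2ccc(F)cc2)c2ccc(C(F)(F)F)cc2)c1)N(O)C(N)=O` is the more potent of the pair: in an assay for inhibition of Polyunsaturated fatty acid 5-lipoxygenase (Homo sapiens), read by HPLC, with stated times of 15 min and 10 min (a lower number here means a stronger inhibitor, a higher number a weaker inhibitor), compound 1 gives 220 nM. Compound 2 `COc1ccc(CNC(=O)c2cccc(C#CC(C)N(O)C(N)=O)c2)c(C(F)(F)F)c1` has the higher number of the two; in this assay compound 2 gives 1700 nM, which stands above compound 1 by a gap that lies beyond the scatter.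

Compound 3 `CC(C#Cc1cccc(C(=O)NCc2ccc(F)cc2C(F)(F)F)c1)N(O)C(N)=O` is the untested member. It differs from compound 2 in one place: fluoro in place of methoxy on an aromatic carbon, the fluoro sitting meta to a trifluoromethyl group and para to a large group. For the measured compounds named here, no measured pair in this set isolates that change, so the size of the step cannot be read off directly. Compound 1, the stronger inhibitor, carries a fluoro on one of its aryl rings, which gives a weak hint that the fluoro-bearing compound 3 may land below compound 2. The step from compound 2 to compound 3 is expected to be a 1.9-fold lower number from compound 2 to compound 3 (0.28 log units; within the scatter), a modest gain in potency. Compound 3 is estimated at 900 nM, with a plausible range from 300 nM to 3000 nM.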

Compound 3, half-maximal inhibitory concentration: 1300 nM
Compound 3: middle estimate off by 1.4-fold (0.16 log units), on the low side; low and high end bracket the measured number.
By their numbers in this assay, from the lowest: compound 1; then compounds 3 and 2 (each within the scatter of the next).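

In this assay there is a 1.3-fold lower number from compound 2 to compound 3 (0.12 log units; within the scatter) for fluoro in place of methoxy on this aromatic carbon, para to a large group and meta to a trifluoromethyl group. For the compounds shown here, this is the first measured pair to isolate the position, and it shows that the methoxy, with its carbon and its oxygen, can give way to a single fluorine without a step beyond the scatter. Nothing measured here bears on why the two readings sit so close together.

The compounds shown leave open whether a different group on this carbon, such as an amine, a nitrile or a carboxylic acid, would shift the number beyond the scatter, or whether this carbon tolerates such variety as well as it tolerates the exchange of methoxy for fluoro. They also leave open what the neighbouring trifluoromethyl group contributes, since it stays in place across this pair and a chloro or a methyl group in its stead would be needed to isolate that position.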